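The compounds below may be only part of what the source reports. "The series", "measured", "known", "first", "only" and "open" are said of these compounds alone.

In a functional assay on SGC-7901 cells (Homo sapiens) for antiproliferative activity, read by sulforhodamine B assay, with a stated time of 72 h (on this read-out lower numbers stand for stronger inhibition and higher numbers for weaker inhibition), compound 1 `S=C(N/N=C/c1ccc2ccccc2n1)Nc1ccc(Cl)cc1` gives 87600 nM. Compound 2 `S=C(N/N=C/c1ccc2ccccc2n1)Nc1ccccc1Br` gives > 100000 nM, which is a limit of the assay and not a number. For the measured compounds named here, its standing is therefore known only as a limit, and the one measured step, an at least 1.1-fold higher number from compound 1 to compound 2 (0.05 log units; that floor lies within the scatter), gives only a floor. Compound 3 `Fc1ccc(NC(=S)N/N=C/c2ccc3ccccc3n2)cc1` differs from compound 2 by 4-fluorophenyl in place of 2-bromophenyl on an amide-type nitrogen. The closer guide is compound 1, which carries 4-chlorophenyl on that nitrogen and reads 87600 nM. A modest step towards stronger inhibition is therefore expected in this assay, although compound 3 may also reach the limit. The estimate means an at least 1.4-fold lower number from compound 2 to compound 3 (0.15 log units; that floor lies within the scatter), as an expected change. For compound 3, the expected value is 70000 nM, within an estimated range of 30000 nM to 100000 nM.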

Compound 3, half-maximal inhibitory concentration: 32300 nM
Estimate against measurement, compound 3: 2.2-fold (0.34 log units) above; the range from low to high includes it.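

Fluoro in place of chloro on an aromatic carbon gives a 2.7-fold lower number from compound 1 to compound 3 (0.43 log units; beyond the scatter), so in this assay a change this small on the amide-type nitrogen whose other neighbour is the thiocarbonyl carbon moves the read-out beyond the scatter, which the earlier step could not show. The change to 4-fluorophenyl in place of 2-bromophenyl gives an at least 3.0-fold lower number from compound 2 to compound 3 (0.49 log units; beyond the scatter), and this is only a floor, although it now lies beyond the scatter. Compound 2 gives > 100000 nM, which is a limit of the assay and not a number: the limit of > 100000 nM in this assay, at which 1 of the 3 values shown sits.

The compounds shown leave open whether the bromine or its place on the ring in 2-bromophenyl sets that limit. They also leave open how a phenyl group carrying an amine or a carboxylic acid would read on that nitrogen.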